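A Methyl on the Allyl Chain of Compound 1

The source may report more compounds than this note shows. Statements on the series, on what has been measured and on what is new or still open speak of the compounds shown alone.

Compound 1 `C=CC[N+](C)(C)c1cccc(O)c1` is the reference point. In a functional assay with Cavia porcellus as the target (on this read-out lower numbers stand for stronger inhibition and higher numbers for weaker inhibition), compound 1 gives 13000 nM, the highest of the two numbers in the set. Compound 3 `C=CC[N+](C)(C)c1cccc(OC(C)=O)c1` gives 3870 nM in this assay; the acetyl in place of hydrogen on an oxygen on the aromatic ring produces a 3.4-fold lower number from compound 1 to compound 3 (0.53 log units; beyond the scatter). Compound 2 `C=CC[N+](C)(C)c1cccc(OC)c1` has only a limit in this assay, > 3000 nM. Because of the limit of > 3000 nM in this assay, at which 1 of the 3 values shown sits, the step from compound 1 to compound 2 cannot be sized, and the same holds for the pair compound 2 and compound 3.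

Compound 4 `C=C(C)C[N+](C)(C)c1cccc(O)c1` is not yet measured. It differs from compound 1 by methyl in place of hydrogen on a double-bonded chain carbon bound to a saturated chain carbon: the allyl becomes 2-methylprop-2-en-1-yl. Every measured step altered the oxygen on the aromatic ring and left the allyl chain untouched, so none of them bears directly on this change. Among the compounds with values here, with no comparable step in hand, the expectation is a step no larger than the scatter. Compound 4 is therefore estimated at 13000 nM, between 4500 nM and 40000 nM. The expected step is no change at the digits printed from compound 1 to compound 4 (within the scatter).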

Compound 4, half-maximal inhibitory concentration: > 3000 nM
Compound 4: only a limit was reported (the forecaster's own chance of this, stated with the estimate: 15%); the middle value does not contradict the limit.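

Compound 4 gives only a limit in this assay, > 3000 nM. The step from compound 1 to compound 4 therefore cannot be read, and no new step can be sized: the limit of > 3000 nM in this assay, at which 2 of the 4 values shown sit.

On these data alone, whether methyl in place of hydrogen on the allyl chain strengthens or weakens inhibition stays open.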